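The source may report more compounds than this note shows. Statements on the series, on what has been measured and on what is new or still open speak of the compounds shown alone.

Measured so far:
compound 1 (`C[C@@H]1CN(C(=O)c2nc(Nc3cc(C4CC4)[nH]n3)c3cc(Cl)ccc3n2)CCN1C(=O)OCc1ccccc1`) 86.2%
compound 2 (`COC(=O)N1CCN(C(=O)c2nc(Nc3cc(C4CC4)[nH]n3)c3cc(Cl)ccc3n2)C[C@H]1C`) 84.6%

In an ADME assay on a cell-free system (plasma, Homo sapiens), read by HPLC, with a stated time of 120 min, at 37 degrees C (on this read-out higher numbers stand for a more stable compound and lower numbers for a less stable compound), compound 1 gives 86.2% and lies within the scatter of compound 2. Compound 3 (`CCOC(=O)N1CCN(C(=O)c2nc(Nc3cc(C4CC4)[nH]n3)c3cc(Cl)ccc3n2)C[C@H]1C`) carries ethoxycarbonyl where compound 1 carries benzyloxycarbonyl: methyl in place of phenyl on a saturated chain carbon bound to an oxygen next to a carbonyl group. Among the compounds with values here, the only measured step at this place is a number 1.6 percentage points lower from compound 1 to compound 2 (within the scatter), where hydrogen takes the place of phenyl. No step beyond the scatter is therefore expected in this assay, and the estimated one is a number 1.2 percentage points lower from compound 1 to compound 3 (within the scatter). Compound 3 is expected at 85%, with an estimated range of 76% to 93%.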

Compound 3, percent of the compound remaining: 85.3%
The estimate for compound 3 lay 0.3 percentage points below the measured number; low and high end bracket the measured number.
By their numbers in this assay, from the lowest: compounds 2, 3 and 1 (each within the scatter of the next).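

In this assay, methyl in place of phenyl gives a small step (a number 0.9 percentage points lower from compound 1 to compound 3 (within the scatter)), and methyl in place of hydrogen gives another (a number 0.7 percentage points higher from compound 2 to compound 3 (within the scatter)), both at the saturated chain carbon bound to an oxygen next to a carbonyl group. Hydrogen, methyl and phenyl at this place are therefore not separated by this read-out, so the ethoxycarbonyl group fits the same flat picture as methoxycarbonyl and benzyloxycarbonyl. No measurement at hand offers a reason for this.

From the compounds shown here alone, whether an amine, a carboxylic acid or a longer chain at this place would also stay within the scatter remains open.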